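The compounds below may be only part of what the source reports. "The series", "measured", "known", "first", "only" and "open" are said of these compounds alone.

Measured compounds:
compound 1, `CCCCCC(=O)Nc1nnc(-c2cc(I)c(O)c(OC)c2)s1`, 1.47 nM
compound 2, `CCCCCCCCC(=O)Nc1nnc(-c2cc(I)c(O)c(OC)c2)s1`, 0.34 nM
compound 3, `CCCCCCC(=O)Nc1nnc(-c2cc(I)c(O)c(OC)c2)s1`, 6.07 nM

All three were tested in an in vitro assay on HEK-293T cells for antagonist activity at transient receptor potential cation channel subfamily V member 1 (Rattus norvegicus), read by fluorescence and calcium flux, with a stated time of 30 min; on this read-out lower numbers stand for stronger inhibition and higher numbers for weaker inhibition. Compound 1 stands second highest of the three numbers: its nearest neighbour is compound 3, and the step of a 4.1-fold higher number from compound 1 to compound 3 (0.62 log units; beyond the scatter); the furthest is compound 2, with the step of a 4.3-fold lower number from compound 1 to compound 2 (0.64 log units; beyond the scatter). Between the other two, the step of an 18-fold higher number from compound 2 to compound 3 (1.25 log units; beyond the scatter). Every one of these steps changes only the length of the saturated chain attached to the carbonyl, and none of them touches the aromatic ring.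

Compound 4, `CCCCCC(=O)Nc1nnc(-c2ccc(O)c(OC)c2)s1`, is not yet measured. It differs from compound 1 in one place: hydrogen in place of iodo on an aromatic carbon. For the measured compounds named here, no measured step bears on a change at this position, so the measured steps give no direction and no size to expect for this change in this assay; the chain is the same as in compound 1, which is the only anchor.

With that anchor alone, compound 4 is expected to give about 8 nM, within a wide range from 1.5 nM to 60 nM. This estimate means a step of a 5.4-fold higher number from compound 1 to compound 4 (0.74 log units; beyond the scatter), which is offered only as a cautious guess, since nothing measured here speaks to it.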

Compound 4, half-maximal inhibitory concentration: 2.61 nM
Compound 4: the middle estimate sits 3.1-fold (0.49 log units) above what was measured; low and high end bracket the measured number.
By their numbers in this assay, from the lowest: compound 2; then compounds 1 and 4 (each within the scatter of the next); then compound 3.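

In this assay, hydrogen in place of iodo on the aromatic carbon ortho to the hydroxy group gives a 1.8-fold higher number from compound 1 to compound 4 (0.25 log units; within the scatter) and so cannot be told apart from no change at all, which means that, with the chain of compound 1, this iodine atom is not needed for the inhibition seen. For the compounds shown here, this is the first look at the aromatic ring in this set: the earlier steps changed only the saturated chain and all lay beyond the scatter, whereas this one, which removes a whole heavy atom from the ring, does not. No measurement available here accounts for why this swap leaves so little trace in the read-out.

Going by these compounds, whether hydrogen in place of iodo would be just as quiet on the longer chains of compound 2 and compound 3 remains open, as a single pair on one chain cannot settle that. Also open, on these data alone, is what other groups on this same aromatic carbon, such as chloro, bromo, methyl or an amine, would do to the inhibition.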